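The compounds below may be only part of what the source reports. "The series", "measured", "known", "first", "only" and "open" are said of these compounds alone.

Three compounds share a core and were measured in a physicochemical assay for solubility, read by HPLC, in phosphate buffer, measured as thermodynamic solubility, with a stated time of 5 days, at pH 2, tested at 10 mM; a higher number here means a more soluble compound, a lower number a less soluble compound. Compound 1, `CC(C)(O)CNC(=O)c1nc(CC2CCCCC2)c(-c2ccc(S(=O)(=O)NC3(C#N)CC3)c3ccccc23)s1`, reaches only a limit of the assay in this assay, at < 1000 nM. Compound 2, `CC(C)(C)NS(=O)(=O)c1ncc(-c2sc(C(=O)N[C@H]3C[C@H](C(=O)O)C3)nc2CC2CCCCC2)c2ccccc12`, likewise gives a limit of < 1000 nM in this assay. Compound 3, `CC(C)(C)NS(=O)(=O)c1ccc(-c2sc(C(=O)N[C@H]3C[C@H](C(=O)O)C3)nc2CC2CCCCC2)c(Cl)c1`, also reports a limit, < 1000 nM. Because (the limit of < 1000 nM in this assay, at which 3 of the 3 values shown sit), none of the three can be set in order against the others, and compound 2 stands at the same limit as its two companions rather than at a number of its own. Among the compounds with values here, no step between measured compounds is recorded, so nothing shows how far any single change moves the read-out.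

Compound 4, `CC(C)(O)CNC(=O)c1nc(CC2CCCCC2)c(-c2cnc(S(=O)(=O)NC(C)(C)C)c3ccccc23)s1`, is not yet measured. It differs from compound 2 in one place: 2-hydroxy-2-methylpropyl in place of 3-carboxycyclobutyl on an amide-type nitrogen. Compound 1 carries the same 2-hydroxy-2-methylpropyl group on its amide and also sits at the limit. The expected step that the limit leaves unreadable from compound 2 to compound 4 is therefore none beyond the usual scatter, with a fair chance that the result is again only a limit. Compound 4 is expected to give about 500 nM, within an estimated range from 100 nM to 2000 nM.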

Compound 4, solubility: < 4000 nM
Compound 4: a limit, no number; the forecaster's own chance of this, stated with the estimate: 75%; the middle value does not contradict the limit.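

The step from compound 2 to compound 4 in this assay cannot be read: each of the two compounds gives a limit of the assay, not a number. The compounds shown leave open where any of the four truly stands, and whether 2-hydroxy-2-methylpropyl in place of 3-carboxycyclobutyl on an amide-type nitrogen moves the read-out at all.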